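Fluoro for methoxy on a selenocyanate carbamate

A few compounds are considered here, and "the series" means these few. Any claim that something is new, unique, unknown or untested is made for them only; others in the source may bear on it.

The three measured compounds were tested in a functional assay on MCF7 cells (Homo sapiens) for cytotoxicity, read by MTT assay, with a stated time of 72 h; on this read-out higher numbers stand for lower toxicity in this test and lower numbers for higher toxicity in this test:

Compound 1 `COc1ccc(OC(=O)Nc2ccc([Se]C#N)cc2)cc1` gives 74100 nM.
Compound 2 `CC(C)COC(=O)Nc1ccc([Se]C#N)cc1` gives 73000 nM.
Compound 3 `CCCCCCOC(=O)Nc1ccc([Se][Se]c2ccc(NC(=O)OCCCCCC)cc2)cc1` gives 89900 nM.

Compound 1 stands between the other two numbers, but neither neighbour is separated from it by more than the scatter: compound 2 sits almost on the same value, and compound 3 is only slightly further off, still within the scatter. The three compounds therefore show no difference in this assay that can be read as real, even though the carbamate substituent varies from an aryl to an alkyl group and compound 3 carries a diselenide instead of a selenocyanate.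

Compound 4 `N#C[Se]c1ccc(NC(=O)Oc2ccc(F)cc2)cc1` has not yet been measured. It differs from compound 1 in one place: fluoro in place of methoxy on an aromatic carbon. Within the data shown here, no step between measured compounds covers this change, so the expectation can rest only on the flat picture the three compounds give. Since varied carbamate groups left this assay unchanged, compound 4 is expected to give a number near that of compound 1, with a step from compound 1 to compound 4 of a 1.0-fold higher number from compound 1 to compound 4 (0.01 log units; within the scatter), which is not beyond the scatter. The estimate for compound 4 in this assay is 75000 nM, with a range from 40000 nM to 150000 nM.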

Compound 4, concentration lethal to 50% of the cells: 65700 nM
For compound 4 the middle estimate is 1.1-fold (0.06 log units) above the measured one; low and high end bracket the measured number.
By their numbers in this assay, from the lowest: compounds 4, 2, 1 and 3 (each within the scatter of the next).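

Among these compounds, the exchange of methoxy for fluoro, on an aromatic carbon para to a large group, is the first change here that can be read in one place, and in this assay it gives a 1.1-fold lower number from compound 1 to compound 4 (0.05 log units; within the scatter) and so stays within the scatter. At this position the two groups therefore cannot be told apart on this read-out, although the entering fluoro has one heavy atom and no hydrogen-bond acceptor by the count given, while the leaving methoxy has two heavy atoms and one acceptor. The earlier compounds shown here showed only a flat picture across structures that differ in more than one place, whereas this pair shows that same flatness for a single exchange at one position.

Nothing available here bears on why this step is so small.

The compounds shown leave open whether this position would stay as flat with an amine, a carboxylic acid or a longer chain in place of fluoro. They also leave open how a diselenide compares with a selenocyanate when the carbamate group is the same, since no pair shown differs in that one place.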